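Urea aryl swap on the piperidine core: compound 3

The source may hold more compounds than are shown below. What is called first, only, known or untested is meant among the compounds shown, and "the series" means these compounds.

Among the measured compounds shown here, in an assay on CHO cells for agonist activity at transient receptor potential cation channel subfamily V member 1 (Homo sapiens), read by scintillation counting, with a stated time of 5 min, in the presence of a further agent that is not named here (on this read-out higher numbers stand for an effect only at larger amounts of compound and lower numbers for an effect already at smaller amounts), compound 2 `CN(C)C1(Cc2ccccc2)CCN(c2cc(C(F)(F)F)ccc2CNC(=O)Nc2cccc3c(=O)[nH]ccc23)CC1` gives 43.7 nM, the only number in the set; compound 1 `CN(C)C1(Cc2ccccc2)CCN(c2cc(C(F)(F)F)ccc2CNC(=O)Nc2ccc3c(c2)OCC3)CC1` is recorded in this assay as "not active" (no number reported) without a number. Compound 3 `CN(C)C1(Cc2ccccc2)CCN(c2cc(C(F)(F)F)ccc2CNC(=O)Nc2ccc3cnccc3c2)CC1` differs from compound 2 in one place: a group of 10 heavy atoms (9 carbon, 1 nitrogen; one six-membered aromatic ring of carbon only, one six-membered aromatic ring with 1 hetero atom) in place of a group of 11 heavy atoms (9 carbon, 1 nitrogen, 1 oxygen; one six-membered aromatic ring of carbon only, one six-membered aromatic ring with 1 hetero atom), on an amide-type nitrogen. For the measured compounds named here, no step between two measured compounds is available, so the size of the change from compound 2 to compound 3 cannot be read from a precedent. Going by the values given here, the one guide is compound 1, which also lacks the group that compound 2 carries, and compound 1 gives "not active" (no number reported), which points toward a loss rather than a gain. A step beyond the scatter, toward larger amounts of compound, is expected, a 3.7-fold higher number from compound 2 to compound 3 (0.56 log units; beyond the scatter), with wide uncertainty. Compound 3 is therefore estimated at 160 nM, in a range from 40 nM to 800 nM.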

Compound 3, half-maximal effective concentration: "not active" (no number reported)
No number was reported for compound 3, so the estimate cannot be set against anything.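

Among the compounds shown here, compound 3 is recorded as "not active" in this assay without a number, so no step from compound 2 can be read, and no evidence on hand bears on this result. The compounds shown leave open whether the hydrogen-bond donor lost with the group of compound 2 matters for the activity.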